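Piperidine nitrogen substitution in a GIP receptor agonist series

The source may hold more compounds than are shown below. What is called first, only, known or untested is meant among the compounds shown, and "the series" means these compounds.

Measured so far:
- compound 1 `CC(C)OC(=O)N1CCC(Oc2cccc3c2CCN3c2ccc(S(C)(=O)=O)cc2)CC1`: 70%
- compound 2 `CCOC(=O)N1CCC(Oc2ncnc3c2CCN3c2ccc(S(C)(=O)=O)cc2F)CC1`: 135%
- compound 3 `CS(=O)(=O)c1ccc(N2CCc3c(OC4CCN(C(=S)Sc5ccccc5)CC4)ncnc32)c(F)c1`: 103%

In a functional assay on CHO-K1 cells with Glucose-dependent insulinotropic receptor (Homo sapiens) as the target, read by a luciferase reporter, with a stated time of 5 h (on this read-out higher numbers stand for larger maximal responses and lower numbers for smaller maximal responses), compound 2 gives the highest of the three numbers. Compound 3 comes nearest to it, and compound 1 lies furthest off; both of those gaps are beyond the scatter.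

Compound 4 `CC(C)S(=O)(=O)N1CCC(Oc2ncnc3c2CCN3c2ccc(S(C)(=O)=O)cc2F)CC1` differs from compound 2 in one place: isopropylsulfonyl in place of ethoxycarbonyl on an amine nitrogen in a ring. Within the data shown here, the only measured step that touches this position is a number 32 percentage points lower from compound 2 to compound 3 (beyond the scatter), where a bulkier ring-bearing group replaced the ethoxycarbonyl. That group is not the one entering here, so the bearing is loose. The change to isopropylsulfonyl keeps the size of the group close to what leaves and keeps the count of acceptors, so the expected step of a number 20 percentage points lower from compound 2 to compound 4 (beyond the scatter) in this assay is a small drop, possibly within the scatter, and a fall as large as that seen for compound 3 is not expected. Compound 4 is therefore estimated at 115%, with a range from 85% to 145%.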

Compound 4, largest response reached (reported as percent of maximum), in percent of the reference or control that the assay uses: 62%
The estimate for compound 4 lay 53 percentage points above the measured number, outside the stated range (below it).
By their numbers in this assay, from the lowest: compounds 4 and 1 (each within the scatter of the next); then compound 3; then compound 2.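

In this assay, the amine nitrogen in the six-membered ring proves sensitive to what it carries even when the group hardly changes in size: isopropylsulfonyl in place of ethoxycarbonyl gives a number 73 percentage points lower from compound 2 to compound 4 (beyond the scatter), with the count of hydrogen-bond acceptors unchanged. The group bearing the six-membered aromatic ring retains more of the response, with a number 41 percentage points lower from compound 3 to compound 4 (beyond the scatter), so heavy-atom count alone does not order compounds 2, 3 and 4. Nothing measured here bears on why the response differs across these groups.

As far as these compounds go, whether the fall follows the sulfonyl link or the isopropyl on it remains open, and a methylsulfonyl group or an acetyl group on the same nitrogen would separate the two. Also open, from the compounds shown here alone, is whether isopropylsulfonyl would behave alike on the core of compound 1.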